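The compounds below may be only part of what the source reports. "The series", "measured", "known", "first", "only" and "open" are said of these compounds alone.

Compound 1 `COc1ncc(-c2ccc3c(c2)N(c2ccc(C)cc2)C(=O)CO3)cc1NS(=O)(=O)c1ccc(F)cc1`: 5870 nM
Compound 3 `O=C1COc2ccc(-c3cccc(NS(=O)(=O)c4ccc(F)cc4)c3)cc2N1c1ccc(Cl)cc1`: 31600 nM
Compound 2 `COc1ccc(N2C(=O)COc3ccc(-c4cnc5ccccc5c4)cc32)cc1`: a limit only, > 40000 nM

All of these come from a functional assay on A549 cells (Homo sapiens) for antiproliferative activity, read by MTT assay, with a stated time of 72 h; on this read-out higher numbers stand for weaker inhibition and lower numbers for stronger inhibition. Of the two numbers shown, compound 3 has the higher one; compound 1 lies below it by a gap beyond the usual scatter. Compound 4 `O=C1COc2ccc(-c3cccc(NS(=O)(=O)c4ccc(F)cc4)c3)cc2N1C1CCCCC1` has not yet been measured and differs from compound 3 in one place: cyclohexyl in place of 4-chlorophenyl on an amide-type nitrogen in a ring. Among the measured compounds shown here, no step between measured compounds bears on this change, so the expectation rests on compound 3 alone. Taking compound 3 at 31600 nM as the anchor, a step of modest size in either direction is expected, possibly none beyond the scatter. The step of a 1.1-fold higher number from compound 3 to compound 4 (0.04 log units; within the scatter) is expected to be small. Compound 4 is estimated at 35000 nM, in the range 12000 nM to 100000 nM.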

Compound 4, half-maximal inhibitory concentration: 14500 nM
For compound 4 the middle estimate is 2.4-fold (0.38 log units) above the measured one; measured number inside the range.
By their numbers in this assay, from the lowest: compound 1; then compound 4; then compound 3. At a limit, above all of these: compound 2.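

In this assay the change on the amide-type nitrogen gives a 2.2-fold lower number from compound 3 to compound 4 (0.34 log units; beyond the scatter) and so shows that this position responds to its substituent. An aromatic ring is not needed there: cyclohexyl, a non-aromatic ring of carbon only, gives the stronger inhibition of this pair, although both compounds remain weak inhibitors.

From the compounds shown here alone, whether a smaller group such as methyl, a longer alkyl chain or a chain ending in an amine on this nitrogen would move the number further remains open. Nothing measured here gives a cause for this step.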